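The compounds below may be only part of what the source reports. "The series", "measured", "known", "first", "only" and "open" are said of these compounds alone.

Compounds measured so far in a functional assay on COLO 205 cells (Homo sapiens) for inhibition, read by sulforhodamine B assay, with a stated time of 48 h, tested at 50 uM; on this read-out higher numbers stand for more inhibition of growth at the one concentration tested and lower numbers for less inhibition of growth:

- Compound 1 `COc1cccc(/C=C/C(=O)/C=C/c2ccc(OCc3cn(CCCCOc4cc(=O)oc5ccccc45)nn3)c(OC)c2)c1`: 46%
- Compound 2 `COc1cc(/C=C/C(=O)/C=C/c2cccc3ccccc23)ccc1OCc1cn(CCCCOc2cc(=O)oc3ccccc23)nn1`: 50%

In this assay, compound 2 gives 50% and stands level with compound 1 within the scatter, so neither can be set apart. Compound 3 `COc1cc(/C=C/C(=O)/C=C/c2ccco2)ccc1OCc1cn(CCCCOc2cc(=O)oc3ccccc23)nn1` has not yet been measured. It carries furan-2-yl in place of naphthalen-1-yl on a double-bonded chain carbon bound to a double-bonded chain carbon.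

Within the data shown here, only one measured step bears on this place. With naphthalen-1-yl in place of 3-methoxyphenyl, the data show a number 4 percentage points higher from compound 1 to compound 2 (within the scatter). Since that single exchange stayed within the scatter, no shift beyond the scatter is expected here, though one step is thin evidence for a furan-2-yl group. The expected change is a number 4 percentage points lower from compound 2 to compound 3 (within the scatter). The estimate for compound 3 is 46%, with an expected range from 33% to 59%.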

Compound 3, percent growth inhibition at one concentration: 43%
The estimate for compound 3 lay 3 percentage points above the measured number; the measured number falls inside the stated range.
By their numbers in this assay, from the lowest: compounds 3, 1 and 2 (each within the scatter of the next).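

In this assay, furan-2-yl in place of naphthalen-1-yl gives a number 7 percentage points lower from compound 2 to compound 3 (within the scatter), and furan-2-yl in place of 3-methoxyphenyl gives a number 3 percentage points lower from compound 1 to compound 3 (within the scatter). The place on a double-bonded chain carbon bound to a double-bonded chain carbon thus accepts a change from 10 heavy atoms of carbon to 5 heavy atoms with a hydrogen-bond acceptor, and the three groups cannot be set apart there. Nothing at hand explains why the read-out stays within the scatter across these exchanges.

Still open, going by these compounds, is whether an aryl group carrying an amine or a carboxylic acid at this place would move the number beyond the scatter. The compounds shown also leave open whether these three would separate at any other concentration.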